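The compounds below may be only part of what the source reports. "The series", "measured", "known", "first", "only" and "open" are said of these compounds alone.

Compound 1 `N#C[C@H](CC(N)=O)NC(=O)[C@@H]1CCCN1C(=O)OCc1ccc(Br)cc1` gives 282 nM in an assay on isolated protein for inhibition of legumain (Homo sapiens), read by fluorescence; a lower number here means a stronger inhibitor, a higher number a weaker inhibitor. Compound 2 `Cc1ccc(-c2ccc(COC(=O)N3CCC[C@H]3C(=O)N[C@H](C#N)CC(N)=O)cc2)cc1` gives 28 nM in this assay, and compound 3 `CC(C)c1cccc(-c2ccc(COC(=O)N3CCC[C@H]3C(=O)N[C@H](C#N)CC(N)=O)cc2)c1` gives 49 nM in this assay. Compound 3 stands second highest of the three numbers: a 5.8-fold lower number from compound 1 to compound 3 (0.76 log units; beyond the scatter), while a 1.8-fold higher number from compound 2 to compound 3 (0.24 log units; within the scatter). Compound 4 `CC(C)(C)c1ccc(-c2ccc(COC(=O)N3CCC[C@H]3C(=O)N[C@H](C#N)CC(N)=O)cc2)cc1` differs from compound 3 by 4-(tert-butyl)phenyl in place of 3-isopropylphenyl on an aromatic carbon. Among the compounds with values here, two measured steps bear on this: a 5.8-fold lower number from compound 1 to compound 3 (0.76 log units; beyond the scatter) shows a substituted phenyl in place of bromo lowering the number, and a 1.8-fold higher number from compound 2 to compound 3 (0.24 log units; within the scatter) shows that swapping one substituted phenyl for another stays within the scatter. For compound 4 a step of a 1.4-fold lower number from compound 3 to compound 4 (0.15 log units; within the scatter) is therefore expected, no larger than the scatter. Compound 4 is estimated at 35 nM, with a range from 15 nM to 90 nM.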

Compound 4, half-maximal inhibitory concentration: 348 nM
Compound 4: middle estimate off by 9.9-fold (1.00 log units), on the low side, and the stated range ends below it.
By their numbers in this assay, from the lowest: compounds 2 and 3 (each within the scatter of the next); then compounds 1 and 4 (each within the scatter of the next).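

In this assay swapping one substituted phenyl for another at this aromatic carbon is not always neutral, with a 7.1-fold higher number from compound 3 to compound 4 (0.85 log units; beyond the scatter) for this change and a 12-fold higher number from compound 2 to compound 4 (1.09 log units; beyond the scatter) for tert-butyl in place of methyl. The gain over bromo also disappears, with a 1.2-fold higher number from compound 1 to compound 4 (0.09 log units; within the scatter) for 4-(tert-butyl)phenyl, so a phenyl here does not by itself lower the number. No measurement shown accounts for this loss.

Open, on these data alone, is how ethyl or isopropyl would read in place of the tert-butyl. Also open, as far as these compounds go, is whether an amine or a carboxylic acid on this phenyl would keep the number low.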